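This account rests on a few compounds, and the source may have more. Where it says the series, first, only, none or still open, it means among the compounds named here.

Working notes on the series. Compound 1 `COc1cc(O)c(C(=O)/C=C/c2ccc(O)c(O)c2)c(OC)c1` gives 31600 nM in a functional assay on B16-F10 cells (Mus musculus) for inhibition, with a stated time of 4 days; a higher number here means a weaker inhibitor, a lower number a stronger inhibitor. Compound 2 `COc1cc(O)c(C(=O)/C=C/c2ccccc2O)c(OC)c1` gives 2300 nM in this assay, and compound 3 `CCc1ccccc1/C=C/C(=O)c1c(O)cc(OC)cc1OC` gives 2500 nM in this assay. Going by the values given here, the single measured step between neighbours, a 1.1-fold higher number from compound 2 to compound 3 (0.04 log units; within the scatter), shows that swapping hydroxy for ethyl on an aromatic carbon left the number essentially where it was. Compound 3 thus holds the second highest of the three numbers: its value sits within the scatter of compound 2, while the value of compound 1 lies well above it, beyond the scatter.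

Compound 4 `COc1cc(O)c(C(=O)/C=C/c2ccccc2C(C)C)c(OC)c1` is the next step from compound 3. The change is methyl in place of hydrogen on a saturated chain carbon bound to an aromatic carbon and a saturated chain carbon, or, read one bond further out, ethyl to isopropyl. Only a 1.1-fold higher number from compound 2 to compound 3 (0.04 log units; within the scatter) speaks to this position, and that step was within the scatter. Among the compounds with values here, no step in the set tells whether adding a methyl on the saturated chain carbon bound to an aromatic carbon moves the number. The expectation for compound 4 is therefore a step of a 1.0-fold higher number from compound 3 to compound 4 (0.02 log units; within the scatter), no clearer than the scatter. Compound 4 is estimated at 2600 nM, with a range from 1000 nM to 7000 nM.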

Compound 4, half-maximal inhibitory concentration: 2700 nM
Estimate against measurement, compound 4: 1.0-fold (0.02 log units) below; the range from low to high includes it.
By their numbers in this assay, from the lowest: compounds 2, 3 and 4 (each within the scatter of the next); then compound 1.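

Methyl in place of hydrogen on a saturated chain carbon bound to an aromatic carbon and a saturated chain carbon produces no clear move in this assay (a 1.1-fold higher number from compound 3 to compound 4 (0.03 log units; within the scatter)), so ethyl to isopropyl is the first change read at this chain carbon, and it stays within the scatter. The direct comparison of the hydroxy and isopropyl compounds also stays within the scatter (a 1.2-fold higher number from compound 2 to compound 4 (0.07 log units; within the scatter)), so hydroxy, ethyl and isopropyl cannot be told apart at this place by these numbers. No measurement is available that bears on this result.

On these data alone, whether an amine, a carboxylic acid or a longer chain on this aromatic carbon would move the number remains open. Also open, as far as these compounds go, is which difference sets compound 1 (31600 nM) apart, as it differs from the other three in more than one place.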